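Indole Isomer Swap on a Non-Cytotoxic Pyrimidine Series

The source may hold more compounds than are shown below. What is called first, only, known or untested is meant among the compounds shown, and "the series" means these compounds.

The series shares one core bearing a trifluoromethoxy-phenyl amine and a variable aromatic group. Compound 1 `FC(F)(F)Oc1ccc(Nc2cc(-c3ccc4[nH]ccc4c3)ncn2)cc1` carries 1H-indol-5-yl there; compound 2 `NC(=O)c1ccccc1-c1cc(Nc2ccc(OC(F)(F)F)cc2)ncn1` carries 2-carbamoylphenyl; compound 3 `CC(C)Cn1cc(-c2cc(Nc3ccc(OC(F)(F)F)cc3)ncn2)cn1` carries 1-isobutyl-1H-pyrazol-4-yl. All three were examined in an ADME assay on BaF3 cells (Mus musculus) for cytotoxicity; on this read-out higher numbers stand for an effect only at larger amounts of compound and lower numbers for an effect already at smaller amounts. Compound 1 gives only a limit, > 10000 nM. Compound 2 likewise gives only a limit, > 10000 nM. Compound 3 also gives only a limit, > 10000 nM, so its position on the numbers is not a number at all but the edge of what this assay reports. Accordingly the change from compound 1 to compound 2 is a step that the two limits leave unreadable from compound 1 to compound 2, the change from compound 1 to compound 3 is a step that the two limits leave unreadable from compound 1 to compound 3, and the change from compound 2 to compound 3 is a step that the two limits leave unreadable from compound 2 to compound 3. Every measured value sits at the limit of > 10000 nM in this assay, at which 3 of the 3 values shown sit.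

Compound 4 `FC(F)(F)Oc1ccc(Nc2cc(-c3cccc4[nH]ccc34)ncn2)cc1` is the next member, differing from compound 3 as follows: 1H-indol-4-yl in place of 1-isobutyl-1H-pyrazol-4-yl on an aromatic carbon. For the measured compounds named here, none of the measured steps can be read, so no size or direction can be drawn from them. Because all three measured values sit at the limit of > 10000 nM in this assay, at which 3 of the 3 values shown sit, compound 4 is expected to show the same behaviour, an expected step that the limit leaves unreadable from compound 3 to compound 4. The estimate for compound 4 in this assay is 15000 nM, with a range from 7000 nM to 40000 nM.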

Compound 4, half-maximal effective concentration: 3790 nM
Estimate against measurement, compound 4: 4.0-fold (0.60 log units) above; the whole stated range lies above it.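

In this assay, for the compounds shown here, the 1H-indol-4-yl group brings the first reading at this position that falls inside the range the assay reports, and the indole attachment alone matters here: replacing 1H-indol-5-yl gives an at least 2.6-fold lower number from compound 1 to compound 4 (0.42 log units; beyond the scatter). The same group gives an at least 2.6-fold lower number from compound 2 to compound 4 (0.42 log units; beyond the scatter) when it replaces 2-carbamoylphenyl and an at least 2.6-fold lower number from compound 3 to compound 4 (0.42 log units; beyond the scatter) when it replaces 1-isobutyl-1H-pyrazol-4-yl, so this position can change the cytotoxicity read-out, and a change of indole isomer is enough to do so. The steps among compound 1, compound 2 and compound 3 cannot be read, and those compounds could show no such difference, each giving only a limit: the limit of > 10000 nM in this assay, at which 3 of the 4 values shown sit.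

From the compounds shown here alone, the true size of all three new steps stays open, since each rests on a limit on one side, and it is unclear whether the lower number belongs to the 1H-indol-4-yl attachment specifically or would also appear with 1H-indol-6-yl or 1H-indol-7-yl. Also open, going by these compounds, is whether the indole hydrogen on nitrogen takes part, which a methyl group on that nitrogen would test.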